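Anilinoquinazoline sulfonamide series: replacing the ethynylphenyl headgroup

The source may hold more compounds than are shown below. What is called first, only, known or untested is meant among the compounds shown, and "the series" means these compounds.

Measured compounds:
compound 1, `C#Cc1cccc(Nc2ncnc3cc(OC)c(OCCCCC(=O)Nc4ccc(S(N)(=O)=O)cc4)cc23)c1`: 17700 nM
compound 2, `COc1ccc(Nc2ncnc3cc(OC)c(OCCCCC(=O)Nc4ccc(S(N)(=O)=O)cc4)cc23)cc1OC`: 35400 nM

Within the data shown here, in a functional assay on A-431 cells (Homo sapiens) for antiproliferative activity, read by MTT assay, with a stated time of 72 h (on this read-out lower numbers stand for stronger inhibition and higher numbers for weaker inhibition), compound 1 gives the lower of the two numbers measured so far; its nearest neighbour is compound 2, and the step of a 2.0-fold higher number from compound 1 to compound 2 (0.30 log units; within the scatter) does not exceed the scatter. Compound 3, `COc1cc2ncnc(Nc3ccc(OC(F)(F)F)cc3)c2cc1OCCCCC(=O)Nc1ccc(S(N)(=O)=O)cc1`, is not yet measured in this assay. It differs from compound 1 in one place: 4-(trifluoromethoxy)phenyl in place of 3-ethynylphenyl on a nitrogen on an aromatic ring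

Among the measured compounds shown here, only one measured step bears on this change. The step from compound 1 to compound 2 also swaps the 3-ethynylphenyl on the nitrogen on an aromatic ring for a differently substituted phenyl, and it came out as a 2.0-fold higher number from compound 1 to compound 2 (0.30 log units; within the scatter), within the scatter. For the measured compounds named here, no measured pair shows 4-(trifluoromethoxy)phenyl itself. On that evidence, a step in this assay of at most the size seen for compound 2, in the direction of a higher number, is expected for compound 3, with a fair chance of no change beyond the scatter.

Compound 3 is therefore estimated at 28000 nM, with a range from 12000 nM to 70000 nM. This corresponds to an expected step of a 1.6-fold higher number from compound 1 to compound 3 (0.20 log units; within the scatter).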

Compound 3, half-maximal inhibitory concentration: 22500 nM
Compound 3: middle estimate off by 1.2-fold (0.09 log units), on the high side; the range from low to high includes it.
By their numbers in this assay, from the lowest: compounds 1, 3 and 2 (each within the scatter of the next).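

Working notes on the group on the aromatic-ring nitrogen: in this assay, the third headgroup adds a fluorine-bearing substituent to the comparison, with a 1.3-fold higher number from compound 1 to compound 3 (0.10 log units; within the scatter) and a 1.6-fold lower number from compound 2 to compound 3 (0.20 log units; within the scatter). The 3-ethynylphenyl, 3,4-dimethoxyphenyl and 4-(trifluoromethoxy)phenyl groups therefore cannot be told apart at this position, although they differ in their atoms and in the triple bond that leaves with 3-ethynylphenyl. Each exchange among the three compounds stays within the scatter, so this set gives no ranking of the headgroups and no substituent on the phenyl ring that stands out.

As far as these compounds go, it remains open whether a phenyl ring carrying an amine or a carboxylic acid would separate from these three compounds in this assay. From the compounds shown here alone, it is also open whether an unsubstituted phenyl or a pyridine ring on the same nitrogen would do so, or whether a longer chain to the sulfonamide-bearing amide would change the picture. No supporting measurement is available to account for the closeness of these values.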